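A few compounds are considered here, and "the series" means these few. Any claim that something is new, unique, unknown or untested is made for them only; others in the source may bear on it.

Working notes on the series. Compound 1 `COc1cc(Cl)cc(-c2nn(-c3cccc(NC(=O)Nc4ccc(Cl)c(Cl)c4)c3)cc2-c2ccncc2)c1` gives -17% in a functional assay on KM12 cells (Homo sapiens) for inhibition, read by sulforhodamine B assay, with a stated time of 48 h, tested at 100 uM; on this read-out lower numbers stand for a stronger effect and higher numbers for a weaker effect at the one concentration tested. Going by the values given here, compound 2 `COc1cc(Cl)cc(-c2nn(-c3cccc(NC(=O)Nc4cccc(C(F)(F)F)c4)c3)cc2-c2ccncc2)c1` gives -48% in this assay, and the only step recorded so far, a number 31 percentage points lower from compound 1 to compound 2 (beyond the scatter), is large. On the two numbers available compound 2 therefore stands lowest, with compound 1 the nearest and higher value.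

Compound 3 `COc1cc(Cl)cc(-c2nn(-c3cccc(NC(=O)c4cccc(C(F)(F)F)c4)c3)cc2-c2ccncc2)c1` differs from compound 2 in one place: 3-(trifluoromethyl)phenyl in place of (3-(trifluoromethyl)phenyl)amino on a carbonyl carbon. Among the compounds with values here, the measured step from compound 1 to compound 2 changes the aryl ring on the urea and leaves the carbonyl-bearing linkage untouched, so no recorded step bears directly on the present change; the series gives no guide to what the removal of the hydrogen-bond donor does in this assay. A shift toward a weaker effect, or a step within the scatter, is the working expectation for compound 3, written as a number 23 percentage points higher from compound 2 to compound 3 (beyond the scatter). Compound 3 is estimated at -25% in this assay, with a range from -55% to 5%.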

Compound 3, a percentage reported as activity, at one concentration (the size of the read-out at that concentration, not a potency): 28%
Estimate against measurement, compound 3: 53 percentage points below; the whole stated range lies below it.
By their numbers in this assay, from the lowest: compound 2; then compound 1; then compound 3.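

The amino nitrogen on the carbonyl carbon matters far more in this assay than the earlier ring change alone could show: with the 3-(trifluoromethyl)phenyl ring kept, losing that nitrogen gives a number 76 percentage points higher from compound 2 to compound 3 (beyond the scatter) and leaves compound 3 the weakest of the three. The comparison with the 3,4-dichlorophenyl urea points the same way, at a number 45 percentage points higher from compound 1 to compound 3 (beyond the scatter) in a change that also replaces the ring, so it cannot separate the linkage from the ring substituents. Nothing on hand accounts for this loss of effect.

As far as these compounds go, whether the amino nitrogen itself is required remains open, since a methylene group or an oxygen atom in its place, as in a carbamate, would separate the presence of that nitrogen from the length of the linkage. From the compounds shown here alone, it is also open whether a 3,4-dichlorophenyl amide would follow compound 3.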